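The source may report more compounds than this note shows. Statements on the series, on what has been measured and on what is new or still open speak of the compounds shown alone.

In a functional assay on A549 cells (Homo sapiens) for antiproliferative activity, read by MTT assay, with a stated time of 72 h (a lower number here means a stronger inhibitor, a higher number a weaker inhibitor), compound 1 (`Cc1ccc(S(=O)(=O)NC(=N)N2CCN(c3cc4c(cc3F)c(=O)c(C(=O)O)cn4C3CC3)CC2)cc1`) gives 71 nM and compound 2 (`N=C(NS(=O)(=O)c1ccccc1Cl)N1CCN(c2cc3c(cc2F)c(=O)c(C(=O)O)cn3C2CC2)CC1`) gives 71 nM while compound 3 (`N=C(NS(=O)(=O)c1ccc(C(F)(F)F)cc1)N1CCN(c2cc3c(cc2F)c(=O)c(C(=O)O)cn3C2CC2)CC1`) gives 71 nM as well, so compound 3 stands level with both. The change to compound 4 (`N=C(NS(=O)(=O)c1ccccc1C(F)(F)F)N1CCN(c2cc3c(cc2F)c(=O)c(C(=O)O)cn3C2CC2)CC1`) is 2-(trifluoromethyl)phenyl in place of 4-(trifluoromethyl)phenyl on a sulfonyl sulfur. The closest measured change, no change at the digits printed from compound 2 to compound 3 (within the scatter) on that same sulfonyl sulfur, lies within the scatter, as do no change at the digits printed from compound 1 to compound 2 (within the scatter) and no change at the digits printed from compound 1 to compound 3 (within the scatter) in this small set. No step beyond the scatter is therefore expected in this assay for this change. The expected step is no change at the digits printed from compound 3 to compound 4 (within the scatter) in size. For compound 4 the estimate is 71 nM with an expected range of 35 nM to 145 nM in this assay here.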

Compound 4, half-maximal inhibitory concentration: 71 nM
Beside the measured number, compound 4's estimate shows no gap at the digits printed, and the stated range covers the measured number.
By their numbers in this assay, from the lowest: compounds 1, 2, 3 and 4 (each within the scatter of the next).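

In this assay, 2-(trifluoromethyl)phenyl in place of 4-(trifluoromethyl)phenyl on a sulfonyl sulfur gives no change at the digits printed from compound 3 to compound 4 (within the scatter) for a pair with the same atoms joined differently. Trifluoromethyl in place of chloro on an aromatic carbon gives no change at the digits printed from compound 2 to compound 4 (within the scatter) and 2-(trifluoromethyl)phenyl in place of 4-methylphenyl gives no change at the digits printed from compound 1 to compound 4 (within the scatter) in the same assay. No supporting data bear on the cause of these readings.

Open, on these data alone, is whether this flat reading holds for groups on the sulfonyl sulfur other than substituted phenyl, such as a methyl or a longer alkyl chain. As far as these compounds go, an amine or a carboxylic acid on the phenyl ring also remains open.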